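The source may hold more compounds than are shown below. What is called first, only, known or untested is meant among the compounds shown, and "the series" means these compounds.

In a physicochemical assay for solubility (a higher number here means a more soluble compound, a lower number a less soluble compound), compound 1 `CNC(=O)c1cc(C(=O)N[C@H]2[C@@H]3COC[C@@H]32)cc2c1OC[C@H]2c1cccc(OC)c1` gives >= 186 ug/mL, which is a limit and not a number. Compound 2 `CNC(=O)c1cc(C(=O)NC2CC2)cc2c1OC[C@H]2c1cccc(OC)c1` gives >= 161 ug/mL, also a limit. Compound 3 `CC[C@@]1(c2ccccc2)COc2c(C(=O)NC)cc(C(=O)N[C@H]3[C@@H]4COC[C@@H]43)cc21` gives >= 152 ug/mL, again a limit. Compound 4 `CNC(=O)c1cc(C(=O)N[C@H]2[C@@H]3COC[C@@H]32)cc2c1OC[C@H]2c1ccccn1` has not yet been measured. It carries pyridin-2-yl in place of 3-methoxyphenyl on a saturated ring carbon of the core of compound 1 (pyridin-2-yl in place of 3-methoxyphenyl on a saturated ring carbon). Among the measured compounds shown here, the one measured step, a step that the two limits leave unreadable from compound 1 to compound 2, lies at a different place, on an amide-type nitrogen, and gives no size to carry over. For the measured compounds named here, no measured step bears directly on this change, and no shift beyond the scatter is expected in this assay. The expected change is a step that the limit leaves unreadable from compound 1 to compound 4. The estimated value for compound 4 is 190 ug/mL, with an expected range from 120 ug/mL to 320 ug/mL.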

Compound 4, solubility: >= 158 ug/mL
Compound 4 gave a limit, no number; the forecaster's own chance of this, stated with the estimate: 70%; the middle value does not contradict the limit.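

Compound 1 and compound 4 both gave limits rather than numbers, so the step between them cannot be read. The compounds shown leave open whether pyridin-2-yl in place of 3-methoxyphenyl changes the result in this assay at all.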